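The source may hold more compounds than are shown below. What is called first, only, known or untested is meant among the compounds shown, and "the series" means these compounds.

Of the compounds shown here, two built on a shared core have so far been measured in a functional assay on isolated protein for inhibition of Glucose-dependent insulinotropic receptor (Homo sapiens), read by HTRF and cAMP accumulation; on this read-out lower numbers stand for an effect already at smaller amounts and higher numbers for an effect only at larger amounts of compound. Compound 1 `Cc1nc(S(C)(=O)=O)ccc1Oc1ncnc(OC2CCN(C(=O)OC3CCC3)CC2)c1F` gives 13.6 nM, and compound 2 `Cc1nc(S(C)(=O)=O)ccc1Oc1ncnc(OC2CCN(C(=O)OC(C)(C)CF)CC2)c1F` gives 19.9 nM. The two differ only in the group on an oxygen next to a carbonyl group, and across that change the measurement moved a 1.5-fold higher number from compound 1 to compound 2 (0.17 log units; within the scatter). Going by the values given here, of the two numbers known, compound 2 carries the larger one, yet its gap to compound 1 lies within the scatter, so the two cannot be told apart on this evidence.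

Compound 3 `Cc1nc(S(C)(=O)=O)ccc1Oc1ncnc(OC2CCN(C(=O)OC(C)F)CC2)c1F` has not yet been measured. It differs from compound 2 in the same place: 1-fluoroethyl in place of 1-(fluoromethyl)-1-methylethyl on an oxygen next to a carbonyl group. Among the compounds with values here, the only measured step that bears on this is the swap at that very position from compound 1 to compound 2, and that step stayed within the scatter. On this basis, compound 3 is expected to show no step beyond the scatter, a 1.0-fold higher number from compound 2 to compound 3 (0.00 log units; within the scatter), in this assay. The estimate for compound 3 is therefore 20 nM, with a likely range from 8 nM to 50 nM.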

Compound 3, half-maximal effective concentration: 65.5 nM
The estimate for compound 3 lay 3.3-fold (0.52 log units) below the measured number; measured number above the stated range.
By their numbers in this assay, from the lowest: compounds 1 and 2 (each within the scatter of the next); then compound 3.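

In this assay, this position proves sensitive to the group it carries, which the step from compound 1 to compound 2 could not show: 1-fluoroethyl in place of 1-(fluoromethyl)-1-methylethyl on an oxygen next to a carbonyl group gives a 3.3-fold higher number from compound 2 to compound 3 (0.52 log units; beyond the scatter), a modest step but a real one. The same group in place of cyclobutyl gives a 4.8-fold higher number from compound 1 to compound 3 (0.68 log units; beyond the scatter), so compound 3 stands apart from both earlier compounds, while those two remain within the scatter of each other, even though only compound 2 carries a fluorine. Of the three groups compared, 1-fluoroethyl goes with the highest number, but nothing in the data shown explains the shift.

From the compounds shown here alone, with so few compounds, it remains open whether the difference follows the heavy-atom count, which falls from 5 in the group that leaves to 3 in the group that enters, or some other feature of the group. A plain ethyl group would test whether the fluorine in 1-fluoroethyl matters, and a longer chain on the same oxygen would show how far the trend extends, if it is a trend at all.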